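From cyano to carbamoyl on a shared core

This account rests on a few compounds, and the source may have more. Where it says the series, first, only, none or still open, it means among the compounds named here.

Compound 1 `O=C(O)c1ccc(NC(=O)c2ccc(-c3nn[nH]n3)cc2)cc1`: 3.5 mg/kg
Compound 2 `N#Cc1ccc(NC(=O)c2ccc(-c3nn[nH]n3)cc2)cc1`: 19.7 mg/kg

For the measured compounds named here, of the two numbers measured so far in a functional assay on the whole organism (stomach) with Rattus norvegicus as the target (on this read-out higher numbers stand for an effect only at larger amounts of compound and lower numbers for an effect already at smaller amounts), the higher belongs to compound 2, at 19.7 mg/kg. Compound 3 `NC(=O)c1ccc(NC(=O)c2ccc(-c3nn[nH]n3)cc2)cc1` keeps the core of compound 2 but carries carbamoyl in place of cyano on an aromatic carbon.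

Going by the values given here, only one measured step bears on this change. Swapping carboxy for cyano at the same place gave a 5.6-fold higher number from compound 1 to compound 2 (0.75 log units; beyond the scatter), a modest step beyond the scatter. Carbamoyl and carboxy both contain a carbonyl, so compound 3 is expected to move back towards compound 1 in this assay, probably only part of the way. The expected change is a 2.5-fold lower number from compound 2 to compound 3 (0.39 log units; beyond the scatter), towards a lower number. For compound 3 the estimated value is 8 mg/kg, with an expected range of 3 mg/kg to 22 mg/kg.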

Compound 3, dose for 50% inhibition: 33 mg/kg
For compound 3 the middle estimate is 4.1-fold (0.62 log units) below the measured one, and the stated range ends below it.
By their numbers in this assay, from the lowest: compound 1; then compounds 2 and 3 (each within the scatter of the next).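

Swapping cyano for carbamoyl on this aromatic carbon gives a 1.7-fold higher number from compound 2 to compound 3 (0.22 log units; within the scatter), so in this assay these two groups cannot be told apart here, even though carbamoyl adds a hydrogen-bond donor. A carbonyl at this place is therefore not enough to restore the effect at smaller doses: replacing only the hydroxy of the carboxy group with amino gives a 9.4-fold higher number from compound 1 to compound 3 (0.97 log units; beyond the scatter), which leaves carboxy alone among these three groups. Nothing available explains why this exchange matters so much in the whole animal.

The compounds shown leave open whether a methyl ester, which keeps the carbonyl but replaces the hydrogen of the hydroxy with methyl, would stay close to compound 1. They also leave open whether a sulfonic acid, with no carbonyl at all, would do so.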